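Aminothiophene carboxamides: replacing benzylamino by 2-oxopiperidin-1-yl

The source may hold more compounds than are shown below. What is called first, only, known or untested is meant among the compounds shown, and "the series" means these compounds.

Measured so far in a functional assay on A549 cells (Homo sapiens) for inhibition, read by sulforhodamine B assay, with a stated time of 72 h; on this read-out lower numbers stand for stronger inhibition and higher numbers for weaker inhibition:
compound 1 `CCOC(=O)Nc1sc(-c2ccc(Cl)cc2)c(-c2ccc(Cl)cc2)c1C(=O)NC1CC1` gives 39800 nM
compound 2 `Nc1sc(-c2ccc(Cl)cc2)c(-c2ccc(Cl)cc2)c1C(=O)NCc1ccccc1` gives 16300 nM
compound 3 `Nc1sc(-c2ccc(Cl)cc2)c(-c2ccc(Cl)cc2)c1C(=O)N1CCC(=O)CC1=O` gives 4090 nM

Compound 2 stands second highest of the three numbers; its nearest neighbour is compound 1 with a higher number, and compound 3 lies furthest with a lower number, both gaps beyond the scatter.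

Compound 4 `Nc1sc(-c2ccc(Cl)cc2)c(-c2ccc(Cl)cc2)c1C(=O)N1CCCCC1=O` is not yet measured. From compound 2 it differs as follows: 2-oxopiperidin-1-yl in place of benzylamino on a carbonyl carbon

Among the measured compounds shown here, one measured step bears on this change. The step of a 4.0-fold lower number from compound 2 to compound 3 (0.60 log units; beyond the scatter) replaced the same benzylamino group by a closely related six-membered ring bearing two carbonyls. Compound 4 carries a ring with one carbonyl, so a step in the same direction, of similar or somewhat smaller size, is expected in this assay, with the proviso that a single step is thin ground.

The estimate for compound 4 in this assay is 7000 nM, within 3000 nM to 17000 nM, which means an expected step of a 2.3-fold lower number from compound 2 to compound 4 (0.37 log units; beyond the scatter).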

Compound 4, half-maximal inhibitory concentration: 1820 nM
For compound 4 the middle estimate is 3.8-fold (0.59 log units) above the measured one; the measured number lies below the stated range.
By their numbers in this assay, from the lowest: compound 4; then compound 3; then compound 2; then compound 1.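

In this assay, the position on the carbonyl carbon responds more strongly to a ring lactam than compound 3 alone indicated: a 9.0-fold lower number from compound 2 to compound 4 (0.95 log units; beyond the scatter). The second ring carbonyl is not required for this gain, and removing it goes further in the same direction: a 2.2-fold lower number from compound 3 to compound 4 (0.35 log units; beyond the scatter). No evidence on the cause of either step is at hand.

Still open, on these data alone, is whether the ring carbonyl of 2-oxopiperidin-1-yl matters at all, a question that plain piperidin-1-yl on the same carbonyl carbon, compared with compound 4, would address. Also open, as far as these compounds go, is how far the number depends on ring size, for which 2-oxopyrrolidin-1-yl in the same place would be the direct comparison.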